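The source may hold more compounds than are shown below. What is called first, only, known or untested is meant among the compounds shown, and "the series" means these compounds.

Measured compounds:
Compound 1 `C=C1C(=O)O[C@@H]2CC(C)=C([C@@H](C)CCCO)[C@H](O)[C@H]12` gives 8.01% in a functional assay on HL-60 cells (Homo sapiens) for activation, read by flow cytometry, with a stated time of 24 h, tested at 50 uM; a lower number here means a weaker effect, a higher number a stronger effect of the compound at the concentration tested.
Compound 2 `C=C1C(=O)O[C@H]2/C=C(\C)CC/C=C(\C)C[C@H](O)[C@@H]12` gives 96.9% in this assay.

Of the two numbers, compound 1 stands lowest; its nearest neighbour, compound 2, sits higher by a margin that is beyond the scatter. For the measured compounds named here, no single-change step between measured compounds is known, so the account has only these two values to lean on.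

The compound to be measured is compound 3 `C=C1C(=O)O[C@@H]2CC(C)=C([C@@H](C)CCCO)[C@H](OC(=O)C(C)CC)[C@H]12`. It differs from compound 1 in one place: (sec-butyl)carbonyl in place of hydrogen on an oxygen on a saturated carbon. The hydroxy of compound 1 thus becomes a ((sec-butyl)carbonyl)oxy, while the core is kept.

Nothing measured here shows what this kind of change does in this assay. The step of a number 10 percentage points higher from compound 1 to compound 3 (within the scatter) is therefore expected to be modest, upward rather than downward, and quite possibly within the scatter. For compound 3 the estimate is 18%, within a range from 3% to 50%.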

Compound 3, a percentage reported as activity, at one concentration (the size of the read-out at that concentration, not a potency): 28.6%
For compound 3 the middle estimate is 10.6 percentage points below the measured one; the range from low to high includes it.
By their numbers in this assay, from the lowest: compound 1; then compound 3; then compound 2.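

In this assay, for the compounds shown here, the replacement of hydroxy by ((sec-butyl)carbonyl)oxy gives a number 20.6 percentage points higher from compound 1 to compound 3 (beyond the scatter) and so provides the first single-change reading at this oxygen. It shows that the free hydroxy hydrogen is not needed to retain the read-out at the concentration tested, and that the (sec-butyl)carbonyl is accepted here with a gain rather than a loss. No measured evidence here explains the rise.

Going by these compounds alone, with only this one group at this oxygen, it remains open whether the rise is specific to (sec-butyl)carbonyl or would also appear with a smaller acetyl or a longer hexanoyl. On these data alone, it also remains open how a benzoyl or a carbamoyl group would read at this oxygen, and whether any such group would carry the number further up.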